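The source may hold more compounds than are shown below. What is called first, only, known or untested is meant among the compounds shown, and "the series" means these compounds.

Compound 3 `CCCCCCCc1nc(N)n(CC(=O)Nc2ccc(C)cc2)c1-c1ccccc1Br` sits second highest of the three numbers measured in a functional assay on A-375 cells (Homo sapiens) for antiproliferative activity, read by MTT assay, with a stated time of 48 h; a higher number here means a weaker inhibitor, a lower number a stronger inhibitor: compound 3 gives 5200 nM, compound 1 `Nc1nc(CC2CCCCC2)c(-c2ccccc2Br)n1CC(=O)Nc1ccccc1` gives 40600 nM, and compound 2 `COc1ccc(Cc2nc(N)n(CC(=O)Nc3ccccc3)c2-c2ccccc2Br)cc1` gives 1400 nM. Compound 3 thus stands between compound 1, which gives the higher number, and compound 2, which gives the lower number. Compound 4 `Cc1ccc(NC(=O)Cn2c(N)nc(Cc3ccc(C(C)(C)C)cc3)c2-c2ccccc2Br)cc1` has not yet been measured in this assay. It differs from compound 3 in one place: 4-(tert-butyl)phenyl in place of hexyl on a saturated chain carbon bound to an aromatic carbon.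

Among the compounds with values here, only one measured step bears on this change, and it points the same way. From compound 1 to compound 2 a cyclohexyl on the saturated chain carbon bound to an aromatic carbon was replaced by a 4-methoxyphenyl, and that step was a 29-fold lower number from compound 1 to compound 2 (1.46 log units; beyond the scatter). The change into compound 4 likewise swaps a non-aromatic group at that position for a para-substituted phenyl, though the entering group carries tert-butyl rather than methoxy and the leaving group is a chain rather than a ring, so the size of the effect need not repeat. Within the data shown here, compound 2 and compound 3 differ in two places and their values show only that compound 2 gives the lower number.

He therefore expects compound 4 to give a lower number than compound 3, a step of a 4.3-fold lower number from compound 3 to compound 4 (0.64 log units; beyond the scatter) in this assay. His estimate for compound 4 in this assay is 1200 nM, within a range from 400 nM to 3600 nM.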

Compound 4, half-maximal inhibitory concentration: 1400 nM
Estimate against measurement, compound 4: 1.2-fold (0.07 log units) below, and the stated range covers the measured number.
By their numbers in this assay, from the lowest: compounds 2 and 4 (each within the scatter of the next); then compound 3; then compound 1.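

In this assay, a 3.7-fold lower number from compound 3 to compound 4 (0.57 log units; beyond the scatter), so the change from a non-aromatic group to a substituted phenyl on a saturated chain carbon bound to an aromatic carbon has now lowered the number beyond the scatter twice, in a 29-fold lower number from compound 1 to compound 2 (1.46 log units; beyond the scatter) as well. The new step shows that this direction does not depend on a ring leaving, since here an open hexyl chain gives way, nor on the entering group holding oxygen, since 4-(tert-butyl)phenyl is all carbon and has no hydrogen-bond acceptors, and it also holds in a compound that differs elsewhere from compound 1 and compound 2. Nothing available says why the aromatic group gives the lower number at this position, and the result can be reported only as a measured step.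

Whether the ring alone accounts for the step remains open, since an unsubstituted phenyl does not appear at this position, and neither does a shorter chain such as propyl. On these data alone, a phenyl carrying a carboxylic acid or an amine at this position is also absent, so the reach of the pattern beyond methoxy and tert-butyl remains unknown.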